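A few compounds are considered here, and "the series" means these few. Any claim that something is new, unique, unknown or untested is made for them only; others in the source may bear on it.

Measured so far in a functional assay on A549 cells (Homo sapiens) for inhibition, read by MTT assay, with a stated time of 72 h; a lower number here means a stronger inhibitor, a higher number a weaker inhibitor:
- compound 1 `CNC(=O)c1cc(Oc2ccc(Nc3nccc(N4CCCC4)n3)cc2)ccn1`: 3410 nM
- compound 2 `CCN(CC)c1ccc(C(=O)Nc2ccc(Oc3ncnc4ccsc34)cc2)cc1`: 8030 nM

Compound 2, at 8030 nM, has the higher of the two numbers, and its gap to compound 1 lies beyond the scatter. Compound 3 `CN(C)c1ccc(C(=O)Nc2ccc(Oc3ncnc4ccsc34)cc2)cc1` keeps the core of compound 2 and changes one group: dimethylamino in place of diethylamino on an aromatic carbon. This is dimethylamino in place of diethylamino on an aromatic carbon. Among the compounds with values here, no measured pair shows this change, so the expectation is weakly founded. In this assay the expected change is a 1.1-fold lower number from compound 2 to compound 3 (0.06 log units; within the scatter), with no step beyond the scatter. For compound 3 the estimated value is 7000 nM, with an expected range of 2500 nM to 20000 nM.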

Compound 3, half-maximal inhibitory concentration: 20200 nM
For compound 3 the middle estimate is 2.9-fold (0.46 log units) below the measured one, and the stated range ends below it.
By their numbers in this assay, from the lowest: compound 1; then compound 2; then compound 3.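

Replacing diethylamino with dimethylamino, on an aromatic carbon para to a large group, is not a silent change in this assay: it gives a 2.5-fold higher number from compound 2 to compound 3 (0.40 log units; beyond the scatter). Within the data shown here, this is the first single-place comparison, and it shows that this position responds to the change, with diethylamino giving the lower number. No available evidence accounts for the step.

With only these two groups shown at this position, it remains open whether dipropylamino or an unsubstituted amine would extend this direction or break it.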